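This account rests on a few compounds, and the source may have more. Where it says the series, first, only, none or still open, it means among the compounds named here.

Measured so far:
- compound 1, `COc1ccc(/C=C\c2cc(OC)c(OC)c(OC)c2)cc1OCc1ccc(CN2CC[C@H](O)C2)cc1`: 51000 nM
- compound 2, `COc1ccc(/C=C\c2cc(OC)c(OC)c(OC)c2)cc1OCc1ccc(CNCCN(C)C)cc1`: 35000 nM

Both numbers come from an ADME assay on NCM460 cells (Homo sapiens) for cytotoxicity, read by CCK-8 assay, with a stated time of 48 h; a lower number here means a stronger inhibitor, a higher number a weaker inhibitor. Among the two measured compounds, compound 1 has the highest number, and its nearest neighbour is compound 2; the two differ by a 1.5-fold lower number from compound 1 to compound 2 (0.16 log units; within the scatter), so nothing separates them beyond the scatter.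

Compound 3, `COc1ccc(/C=C\c2cc(OC)c(OC)c(OC)c2)cc1OCc1ccc(CO)cc1`, is the unmeasured compound. It differs from compound 1 in one place only: hydroxy in place of 3-hydroxypyrrolidin-1-yl on a saturated chain carbon bound to an aromatic carbon.

Going by the values given here, only one measured step bears on this change, the one at the same place on the saturated chain carbon bound to an aromatic carbon, where a different group replaced the 3-hydroxypyrrolidin-1-yl group and the number moved by a 1.5-fold lower number from compound 1 to compound 2 (0.16 log units; within the scatter). That step stayed within the scatter. With nothing else to go on, the expectation for compound 3 in this assay is a step of about a 1.1-fold higher number from compound 1 to compound 3 (0.03 log units; within the scatter), that is, no movement beyond the scatter, a number close to that of compound 1.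

The estimate for compound 3 is therefore 55000 nM, with a likely range from 20000 nM to 150000 nM.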

Compound 3, half-maximal inhibitory concentration: > 50000 nM
Compound 3 ended at the assay's limit (the forecaster's own chance of this, stated with the estimate: 20%); the middle value does not contradict the limit.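

In this assay compound 3 gives > 50000 nM, which is a limit of the assay and not a number. Going by these compounds alone, this is the first group at this place, on a saturated chain carbon bound to an aromatic carbon, that carries no nitrogen, and swapping in the small hydroxy group for the (2-(dimethylamino)ethyl)amino group gives an at least 1.4-fold higher number from compound 2 to compound 3 (0.15 log units; that floor lies within the scatter), so the number does not fall and the measured floor of the step stays within the scatter, although the true gap could be larger. The step from compound 1 to compound 3, where hydroxy replaces 3-hydroxypyrrolidin-1-yl, cannot be read because of the limit: the limit of > 50000 nM in this assay, at which 1 of the 3 values shown sits.

Going by these compounds, how far the number of compound 3 lies past the limit stays open, and with it the true size of both changes. Also open, on these data alone, is whether a carboxylic acid, a primary amine or a longer chain ending in hydroxy at this place would give a readable number in this assay, and whether any of them would differ from compound 1 beyond the scatter.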